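Aromatic substitution on the shared core and liver microsomal clearance

This account rests on a few compounds, and the source may have more. Where it says the series, first, only, none or still open, it means among the compounds named here.

Measured compounds:
compound 1, `O=C(CCSc1nc2ccccc2o1)N1CCCC1`, 161 mL/min/g
compound 2, `COc1ccc2oc(SCCC(=O)N3CCCC3)nc2c1`, 198 mL/min/g
compound 3, `O=C(CCSc1nc2cc(F)ccc2o1)N1CCCC1`, 115 mL/min/g

All three were run in an ADME assay on microsomes from liver (Mus musculus) for metabolic stability, read by LC-MS, using NADPH, with a stated time of 45 min, tested at 0.5 uM; on this read-out higher numbers stand for fast clearance and lower numbers for slow clearance. Among the three numbers compound 1 stands second highest. Its nearest neighbour is compound 2, with a 1.2-fold higher number from compound 1 to compound 2 (0.09 log units; within the scatter); the furthest is compound 3, with a 1.4-fold lower number from compound 1 to compound 3 (0.15 log units; within the scatter). Between the two substituted compounds the gap is a 1.7-fold lower number from compound 2 to compound 3 (0.24 log units; within the scatter). Among the measured compounds shown here, every step so far lies within the scatter, so the three compounds are best read as one cluster.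

Compound 4, `O=C(CCSc1nc2ccc(Cl)cc2o1)N1CCCC1`, differs from compound 1 by chloro in place of hydrogen on an aromatic carbon. For the measured compounds named here, the step that bears most directly on it is the one from compound 1 to compound 3, where another small group replaced hydrogen on an aromatic carbon without moving the number beyond the scatter; the step from compound 1 to compound 2 points the same way. No step beyond the scatter is therefore expected in this assay, and compound 4 is estimated at 135 mL/min/g, within 75 mL/min/g to 240 mL/min/g, which means an expected step of a 1.2-fold lower number from compound 1 to compound 4 (0.08 log units; within the scatter).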

Compound 4, intrinsic clearance in a liver preparation (reported as CLH), per the amount of preparation that the assay uses: 109 mL/min/g
Estimate against measurement, compound 4: 1.2-fold (0.09 log units) above; measured number inside the range.
By their numbers in this assay, from the lowest: compounds 4, 3, 1 and 2 (each within the scatter of the next).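

In this assay, chloro in place of hydrogen on an aromatic carbon, at the place meta to a fused ring and para to a fused ring, gives a 1.5-fold lower number from compound 1 to compound 4 (0.17 log units; within the scatter). This adds a halogen heavier than fluoro to the small groups already seen on the six-membered aromatic ring, and this place accepts it with no step beyond the scatter, so a single chlorine here does not separate compound 4 from compound 1 on clearance. No measurement is available that bears on the reason for this result.

Still open, on these data alone, is whether an amine or a carboxylic acid at this place would give a step beyond the scatter. The compounds shown also leave open whether a longer chain between the sulfur and the carbonyl would move the number further than any change on the aromatic ring.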